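The source may report more compounds than this note shows. Statements on the series, on what has been measured and on what is new or still open speak of the compounds shown alone.

Measured in a functional assay on MCF7 cells (Homo sapiens) for antiproliferative activity, read by MTT assay; on this read-out higher numbers stand for weaker inhibition and lower numbers for stronger inhibition:
compound 1 `CC/C=C\C/C=C\C/C=C\CCCCCCCC1(O)CC(=O)c2c(O)cc(OCOC)cc2O1`: 17500 nM
compound 2 `CCCC/C=C\CCCCCCCCCc1cc(=O)c2c(O)cc(OCOC)cc2o1`: > 67200 nM
compound 3 `CCCC/C=C\CCCCCCCCCc1cc(=O)c2c(O)c(C)c(OCOC)cc2o1`: > 67200 nM

Compound 2 gives only a limit, not a number, and stands at the limit of > 67200 nM in this assay, at which 2 of the 3 values shown sit. Compound 3 is also a limit, at > 67200 nM. Compound 4 `CC/C=C\C/C=C\C/C=C\CCCCCCCc1cc(=O)c2c(O)cc(OCOC)cc2o1` is still unmeasured. The change leading to it is a group of 10 heavy atoms (10 carbon; no ring) in place of a group of 8 heavy atoms (8 carbon; no ring), on a saturated chain carbon, seven bonds along the chain from an aromatic carbon. Among the measured compounds shown here, the one measured step from compound 2 is a step that the two limits leave unreadable from compound 2 to compound 3, a methyl in place of hydrogen on an aromatic carbon, so it offers no size to carry over. For the measured compounds named here, the only true number is that of compound 1, at 17500 nM, on a different core, so a modest move toward stronger inhibition is expected in this assay. Compound 4 may well stay at the limit. The expected change is an at least 1.3-fold lower number from compound 2 to compound 4 (0.12 log units; that floor lies within the scatter). For compound 4 the estimate is 50000 nM, with an expected range of 20000 nM to 100000 nM.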

Compound 4, half-maximal inhibitory concentration: 17500 nM
Compound 4: middle estimate off by 2.9-fold (0.46 log units), on the high side; measured number outside the range, below it.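

In this assay, among the compounds shown here, putting the group of 10 heavy atoms with 3 double bonds in place of oct-3-en-1-yl gives the first readable step at this position: an at least 3.8-fold lower number from compound 2 to compound 4 (0.58 log units; beyond the scatter). Compound 2 stands only at a limit of the assay, and the size of this step is therefore a floor: the limit of > 67200 nM in this assay, at which 2 of the 4 values shown sit. The change brings the shared core off that limit to a true number, which the methyl step, unreadable between two limits, could not show.

Chain length and the count of double bonds change together here, and which of them carries the step stays open. Also open, as far as these compounds go, is how a fully saturated chain, or an amine on this chain, would read in this assay.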